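The source may hold more compounds than are shown below. What is called first, only, known or untested is meant among the compounds shown, and "the series" means these compounds.

Measured so far:
- compound 1 `Cn1c(-c2ccccc2)nc2c(NC3CCCCC3)ncnc21`: > 30000 nM
- compound 2 `CCn1c(-c2ccccc2)nc2c(NC3CCC3)ncnc21`: 1440 nM
- compound 3 `CCCn1c(-c2ccccc2)nc2c(NC3CCC3)ncnc21`: 774 nM

In a functional assay on CHO cells for antagonist activity at adenosine receptor A2b (Homo sapiens), read by 33P incorporation, with a stated time of 20 min (on this read-out lower numbers stand for stronger inhibition and higher numbers for weaker inhibition), compound 1 gives only a limit, > 30000 nM, and not a number. Among the compounds with values here, compound 2 and compound 3 share the same core and give two numbers that lie within the usual scatter of each other; the step of a 1.9-fold lower number from compound 2 to compound 3 (0.27 log units; within the scatter) is the only measured step here, and it brings methyl in place of hydrogen on a saturated chain carbon, two bonds along the chain from an aromatic nitrogen. So compound 3 stands beside compound 2, with compound 1 sitting at a limit (the limit of > 30000 nM in this assay, at which 1 of the 3 values shown sits).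

Compound 4 `CCCn1c(-c2ccccc2)nc2c(NC3CCCC3)ncnc21` is not yet measured. It differs from compound 3 by cyclopentyl in place of cyclobutyl on a nitrogen on an aromatic ring. Within the data shown here, no measured step changes this ring, so the one measured step, which was within the scatter, gives no direction. The step of a 1.0-fold higher number from compound 3 to compound 4 (0.01 log units; within the scatter) is therefore expected to stay within the scatter. Compound 4 is estimated at 800 nM, with a range from 250 nM to 3000 nM in this assay.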

Compound 4, inhibition constant: 3430 nM
Estimate against measurement, compound 4: 4.3-fold (0.63 log units) below; the measured number lies above the stated range.
By their numbers in this assay, from the lowest: compounds 3 and 2 (each within the scatter of the next); then compound 4. At a limit, above all of these: compound 1.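

Within the data shown here, until now the only measured step had changed the chain on the aromatic nitrogen and stayed within the scatter, whereas in this assay the swap to cyclopentyl in place of cyclobutyl on a nitrogen on an aromatic ring gives a 4.4-fold higher number from compound 3 to compound 4 (0.65 log units; beyond the scatter), the first step here that goes beyond it. So this position does respond to the size of the ring, with cyclobutyl holding the lower number, although that rests on this single pair of compounds with the propyl chain. Nothing measured here explains why the two rings differ.

Still open, as far as these compounds go, is how a cyclopropyl ring, a cyclohexyl ring or an open chain such as isobutyl would read at this nitrogen with the propyl chain kept in place. Compound 1, which carries cyclohexyl, gives only a limit, > 30000 nM, and it also has a different chain, so it cannot settle the matter.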